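The source may report more compounds than this note shows. Statements on the series, on what has been measured and on what is new or still open speak of the compounds shown alone.

Compound 1 `CCCCn1cnc2c(NCc3cccc(Cl)c3)nc(N[C@H]3CC[C@H](N)CC3)nc21`: 4700 nM
Compound 2 `CC(C)CCn1cnc2c(Nc3ccccc3)nc(N[C@H]3CC[C@H](N)CC3)nc21`: 6400 nM

Both compounds were measured in a functional assay on BT-474 cells (Homo sapiens) for inhibition, read by fluorescence, with a stated time of 72 h (on this read-out higher numbers stand for weaker inhibition of growth and lower numbers for stronger inhibition of growth), and compound 2 stands within the usual scatter of compound 1. Compound 3 `CCCCn1cnc2c(Nc3ccccc3)nc(N[C@H]3CC[C@H](N)CC3)nc21` differs from compound 2 by hydrogen in place of methyl on a saturated chain carbon bound to two saturated chain carbons, which turns isopentyl into butyl. For the measured compounds named here, no measured pair isolates this change, and no step beyond the scatter is expected in this assay. Compound 1 also carries butyl and gives 4700 nM. The expected step is a 1.2-fold lower number from compound 2 to compound 3 (0.07 log units; within the scatter). Compound 3 is estimated at 5500 nM, with an expected range of 2500 nM to 12000 nM.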

Compound 3, concentration for 50% growth inhibition: 4900 nM
The estimate for compound 3 lay 1.1-fold (0.05 log units) above the measured number, and the stated range covers the measured number.
By their numbers in this assay, from the lowest: compounds 1, 3 and 2 (each within the scatter of the next).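

In this assay, the change from isopentyl to butyl now has a measured pair of its own, with a 1.3-fold lower number from compound 2 to compound 3 (0.12 log units; within the scatter). For the compounds shown here, compound 3 also gives the first comparison on the nitrogen on an aromatic ring: with butyl held constant, phenyl in place of 3-chlorobenzyl gives a 1.0-fold higher number from compound 1 to compound 3 (0.02 log units; within the scatter). Neither change moves the number beyond the scatter. The compounds shown leave open whether a longer chain, or an amine or a carboxylic acid in place of butyl, would do so. No evidence bearing on these results is available.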